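Side-chain exchange on the shared core: expectation for compound 4

The source may hold more compounds than are shown below. What is called first, only, known or untested is meant among the compounds shown, and "the series" means these compounds.

Measured compounds:
compound 1, `O=C(CC[C@H](NC(=O)c1cc2ccccc2cn1)C(=O)OCc1ccccc1)OCc1ccccc1`, 25.2%
compound 2, `CSCC[C@H](NC(=O)c1cc2ccccc2cn1)C(=O)OCc1ccccc1`, 39.6%
compound 3, `O=C(CNC(=O)c1cc2ccccc2cn1)OCc1ccccc1`, 16.1%

In a functional assay on the whole organism (CCRF S-180 cells, Mus musculus) for inhibition, in a xenograft, with stated times of 7 days and 24 h, at a dose of 100 umol/kg by the intraperitoneal route (on this read-out higher numbers stand for more inhibition at the one dose given (going by the name of the read-out) and lower numbers for less inhibition), compound 1 stands second highest of the three numbers: compound 2 lies above it beyond the scatter, compound 3 below it within the scatter. Compound 4 is `NCCCC[C@H](NC(=O)c1cc2ccccc2cn1)C(=O)OCc1ccccc1`; relative to compound 1 the change is 2-aminoethyl in place of benzyloxycarbonyl on a saturated chain carbon, three bonds along the chain from an amide-type nitrogen and a carbonyl carbon. Among the measured compounds shown here, two measured steps touch the same carbon. Exchange of the benzyloxycarbonyl there gave a number 14.4 percentage points higher from compound 1 to compound 2 (beyond the scatter), while removal of the whole 2-(benzyloxycarbonyl)ethyl gave a number 9.1 percentage points lower from compound 1 to compound 3 (within the scatter). Changes at this carbon thus range from nothing beyond the scatter to a modest rise, so a small rise is expected for compound 4, a number 6.8 percentage points higher from compound 1 to compound 4 (within the scatter). The estimate for compound 4 is 32%, expected to lie between 18% and 48%.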

Compound 4, a percentage reported as inhibition, in the whole organism at one dose (the size of the read-out at that dose, not a potency): 40.6%
The estimate for compound 4 lay 8.6 percentage points below the measured number; the range from low to high includes it.
By their numbers in this assay, from the lowest: compounds 3 and 1 (each within the scatter of the next); then compounds 2 and 4 (each within the scatter of the next).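

In this assay, a chain ending in an amine at this carbon gives a rise over both the benzyloxycarbonyl-bearing chain (a number 15.4 percentage points higher from compound 1 to compound 4 (beyond the scatter)) and hydrogen (a number 24.5 percentage points higher from compound 3 to compound 4 (beyond the scatter)). Against 2-(methylsulfanyl)ethyl, the amine chain gives no separable change (a number 1 percentage points higher from compound 2 to compound 4 (within the scatter)), so the rise over compound 1 does not require the methylsulfanyl end. No evidence on the cause of these steps is available.

Open, from the compounds shown here alone, is how a carboxylic acid in place of the benzyloxycarbonyl would compare. Also open, going by these compounds, is whether a shorter or longer amine chain would hold the level of compound 4.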